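The compounds below may be only part of what the source reports. "The series", "measured", "known", "first", "only" and "open" are said of these compounds alone.

Measured compounds in an assay on HEK-293T cells for antagonist activity at vitamin D3 receptor (Homo sapiens), read by a luciferase reporter, with a stated time of 24 h; on this read-out higher numbers stand for weaker inhibition and lower numbers for stronger inhibition:

- compound 1 `CCC(CC)n1c(-c2ccc(OCc3c(-c4c(Cl)cccc4Cl)noc3C(C)C)cc2F)nc2ccc(C(=O)O)cc21`: > 10000 nM
- compound 2 `CCn1c(-c2ccc(OCc3c(-c4c(Cl)cccc4Cl)noc3C(C)C)cc2)nc2ccc(C(=O)O)cc21`: 5760 nM
- compound 3 `CC(C)c1onc(-c2c(Cl)cccc2Cl)c1COc1ccc(-c2nc3ccc(C(=O)O)cc3n2CC2CCCCC2)cc1`: 346 nM

The value of compound 1 is a limit of this assay, not a number; it is the point (the limit of > 10000 nM in this assay, at which 1 of the 3 values shown sits). Among the two numbers that were obtained, compound 2 stands highest, and its nearest neighbour is compound 3, reached by a 17-fold lower number from compound 2 to compound 3 (1.22 log units; beyond the scatter). For the measured compounds named here, that step is the one measured change on the same saturated chain carbon bound to the aromatic nitrogen, and it ran toward a lower number.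

Compound 4 `CC(C)c1onc(-c2c(Cl)cccc2Cl)c1COc1ccc(-c2nc3ccc(C(=O)O)cc3n2C2CCC2)cc1` is not yet measured. It differs from compound 2 by cyclobutyl in place of ethyl on an aromatic nitrogen. Going by the values given here, the change is of the same kind as the one from compound 2 to compound 3: a small acyclic group on the aromatic nitrogen gives way to a carbocycle. The cyclobutyl is smaller than the cyclohexyl that brought the large drop to compound 3, so the expected step is in the same direction but of reduced size, while still beyond the scatter; the step from compound 2 to compound 4 is estimated at a 3.8-fold lower number from compound 2 to compound 4 (0.58 log units; beyond the scatter). For compound 4 in this assay the expected value is 1500 nM, with a range from 500 nM to 4500 nM.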

Compound 4, half-maximal inhibitory concentration: 1100 nM
For compound 4 the middle estimate is 1.4-fold (0.13 log units) above the measured one; measured number inside the range.
By their numbers in this assay, from the lowest: compound 3; then compound 4; then compound 2. At a limit, above all of these: compound 1.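

On the aromatic nitrogen, a small carbocycle bound straight to the ring also moves the read-out in this assay the same way as the cyclohexylmethyl group, the step being a 5.2-fold lower number from compound 2 to compound 4 (0.72 log units; beyond the scatter), so the lower number at this position is not confined to compound 3. The two ring-bearing groups are still not equal here, as the comparison gives a 3.2-fold higher number from compound 3 to compound 4 (0.50 log units; beyond the scatter), which places cyclobutyl between ethyl and cyclohexylmethyl among the three measured groups at this nitrogen. Nothing measured on these compounds gives a reason for either step.

The compounds shown do not separate ring size from the presence of a chain carbon, since cyclobutyl and cyclohexylmethyl differ in both, and a cyclohexyl bound straight to the aromatic nitrogen or a cyclobutylmethyl group would pull the two apart. Also open, as far as these compounds go, is whether the ring must be carbon only, as a tetrahydropyranyl ring or a piperidine amine at this nitrogen would show, and whether an open chain longer than ethyl, such as n-butyl, runs in the same direction.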